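Replacing 4-chlorophenyl with 4-cyano-2-fluorophenyl in compound 3

This account rests on a few compounds, and the source may have more. Where it says the series, first, only, none or still open, it means among the compounds named here.

In an ADME assay on MT4 cells (Homo sapiens) for cytotoxicity, read by MTT assay, with a stated time of 5 days (a higher number here means that more compound is tolerated, a lower number that less compound is tolerated), three compounds have been read so far. Compound 1 (`N#Cc1ccc(Nc2nccc(OCC(=O)Nc3ccc(Cl)cc3)n2)cc1`) gives 162000 nM as a plain number. Compound 2 (`Cc1cc(OCC(=O)Nc2ccc(F)cc2)nc(Nc2ccc(C#N)cc2)n1`) gives only a limit of the assay (> 331000 nM). Compound 3 (`Cc1cnc(Nc2ccc(C#N)cc2)nc1OCC(=O)Nc1ccc(Cl)cc1`) likewise gives only a limit (> 317000 nM), so its true standing is not known as a number, and it shares that position with one other compound.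

Compound 4 (`Cc1cnc(Nc2ccc(C#N)cc2)nc1OCC(=O)Nc1ccc(C#N)cc1F`) keeps the core of compound 3 and carries 4-cyano-2-fluorophenyl in place of 4-chlorophenyl on an amide-type nitrogen.

Among the compounds with values here, only one measured step bears on this, and only indirectly. That step (an at least 1.9-fold higher number from compound 1 to compound 3 (0.29 log units; that floor lies within the scatter)) puts methyl in place of hydrogen on an aromatic carbon. Within the data shown here, no measured step changes only the group on the amide-type nitrogen, so the size of this change has no direct precedent.

No shift beyond the scatter is therefore expected in this assay, with any movement more likely downward, since compound 3 starts from a limit. The expected step is an at least 1.2-fold lower number from compound 3 to compound 4 (0.10 log units; that floor lies within the scatter) and it stays an estimate. The range is kept wide enough to take in compound 1 at 162000 nM. Compound 4 is estimated at 250000 nM, with an expected range from 90000 nM to 335000 nM.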

Compound 4, half-maximal cytotoxic concentration: > 310000 nM
Compound 4 gave a limit, no number; the forecaster's own chance of this, stated with the estimate: 55%; at least 1.2-fold (0.09 log units) between middle value and limit.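

In this assay compound 4 gives only a limit of the assay, > 310000 nM. Within the data shown here, compound 3 also stands at a limit, so no step from compound 3 to compound 4 can be read. The compounds shown leave open whether 4-cyano-2-fluorophenyl in place of 4-chlorophenyl changes the tolerated concentration at all.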